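Swapping Dimethylamino for Diethylamino: an Unmeasured Step

A few compounds are considered here, and "the series" means these few. Any claim that something is new, unique, unknown or untested is made for them only; others in the source may bear on it.

Measured compounds in a functional assay on MCF7 cells (Homo sapiens) for antiproliferative activity, read by CCK-8 assay, with a stated time of 24 h; a lower number here means a stronger inhibitor, a higher number a weaker inhibitor:
compound 1, `CN(C)Cc1ccc2nc(NC(=O)NN=C(c3ccccn3)c3ccccn3)sc2c1`, gives only the limit > 40000 nM.
compound 2, `CCN(CC)Cc1ccc2nc(NC(=O)NN=C(c3ccccn3)c3ccccn3)sc2c1`, gives only the limit > 40000 nM.
compound 3, `CN(C)Cc1ccc(NC(=O)NN=C(c2ccccc2)c2ccccc2)cc1`, gives 12100 nM.

Compound 1 and compound 2 differ by diethylamino in place of dimethylamino on a saturated chain carbon bound to an aromatic carbon. The step that the two limits leave unreadable from compound 1 to compound 2 cannot be sized because of the limit of > 40000 nM in this assay, at which 2 of the 3 values shown sit. How the core of compound 3 differs from the core of compound 1 is not broken down here. Going by the values given here, compound 4, `CCN(CC)Cc1ccc(NC(=O)NN=C(c2ccccc2)c2ccccc2)cc1`, has not been measured; it differs from compound 3 by diethylamino in place of dimethylamino on a saturated chain carbon bound to an aromatic carbon, the same change as the one from compound 1 to compound 2. The step of a 1.0-fold lower number from compound 3 to compound 4 (0.00 log units; within the scatter) is expected to be small. This rests on compound 3 at 12100 nM and on the unreadable step that the two limits leave unreadable from compound 1 to compound 2, which gives no sign of a large shift. For compound 4 the estimated value is 12000 nM, with a range from 5000 nM to 30000 nM.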

Compound 4, half-maximal inhibitory concentration: 13100 nM
Compound 4: the middle estimate sits 1.1-fold (0.04 log units) below what was measured; the range from low to high includes it.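

In this assay the change appears as a 1.1-fold higher number from compound 3 to compound 4 (0.03 log units; within the scatter), so on the core of compound 3 the dimethylamino and diethylamino groups cannot be told apart. Going by these compounds alone, this does not show that the result carries over to another core, because the matching step on the core of compound 1 cannot be read: the limit of > 40000 nM in this assay, at which 2 of the 4 values shown sit. Only one core therefore gives a readable size for this change, and a single step makes no pattern across cores.

The compounds shown leave open whether a ring amine such as morpholine, or dipropylamino with its longer chains, would shift the number beyond the scatter at this place on the core of compound 3. They also leave open whether either group would give a readable value on the core of compound 1.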